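The compounds below may be only part of what the source reports. "The series", "measured", "known", "first", "only" and "open" are said of these compounds alone.

Measured compounds in an assay on cells for inhibition of HSP60/HSP10 (Homo sapiens), with a stated time of 60 min; on this read-out higher numbers stand for weaker inhibition and lower numbers for stronger inhibition:
compound 1 `COc1ccc(S(=O)(=O)Nc2ccc(-c3nc4ccccc4o3)cc2)cc1` gives > 100000 nM, which is a limit of the assay and not a number.
compound 2 `Cc1cccc(S(=O)(=O)Nc2ccc(-c3nc4ccccc4o3)cc2)c1` gives > 100000 nM, likewise a limit of the assay.
compound 3 `C=Cc1ccc(S(=O)(=O)Nc2ccc3oc(-c4ccccc4)nc3c2)cc1` gives > 100000 nM, again a limit of the assay.

Compound 3 therefore stands at a limit rather than at a measured number, and the same holds for every value shown so far, since (the limit of > 100000 nM in this assay, at which 3 of the 3 values shown sit). Going by the values given here, the one step between measured compounds that differ in a single place, a step that the two limits leave unreadable from compound 1 to compound 2, cannot be read because both of its ends are limits. Among the compounds with values here, no measured step bears directly on the change from compound 3 to compound 4 `COc1ccccc1S(=O)(=O)Nc1ccc2oc(-c3ccccc3)nc2c1`, which is 2-methoxyphenyl in place of 4-vinylphenyl on a sulfonyl sulfur. Within the data shown here, with every measured value at the limit, the series gives no direction and no size of step to carry over to compound 4. Compound 4 is expected to sit at the limit as well, so the step that the limit leaves unreadable from compound 3 to compound 4 is estimated to lie within the scatter. The estimate for compound 4 in this assay is 200000 nM, with a range from 50000 nM to 1000000 nM.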

Compound 4, half-maximal inhibitory concentration: > 100000 nM
Compound 4: only a limit was reported; the forecaster's own chance of this, stated with the estimate: 85%; the middle value is on the limit's open side.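

The step between compound 3 and compound 4 cannot be read, since both of its ends are limits of the assay and not numbers: the limit of > 100000 nM in this assay, at which 4 of the 4 values shown sit.

The compounds shown leave open which group on the sulfonyl sulfur, if any, would give a measurable value in this assay.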